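Removing the carbonyl-bearing group from the ring nitrogen

A few compounds are considered here, and "the series" means these few. Any claim that something is new, unique, unknown or untested is made for them only; others in the source may bear on it.

The series rests on the core of compound 1 `O=C(Nc1cc(C(F)(F)F)cc(C(F)(F)F)c1)C1CCc2ccccc2N1C(=O)c1cccc(Cl)c1`. Within the data shown here, in a functional assay on HCT-15 cells (Homo sapiens) for cytotoxicity, read by sulforhodamine B assay, with a stated time of 72 h (on this read-out higher numbers stand for weaker inhibition of growth and lower numbers for stronger inhibition of growth), compound 1 gives 625 nM, the lowest of the three numbers so far. Compound 2 `CCCCCCCCC(=O)N1c2ccccc2CCC1C(=O)Nc1ccccc1O` gives 38400 nM and compound 3 `CC(=O)N1c2ccccc2CCC1C(=O)Nc1ccccc1O` gives 54500 nM; both lie far above compound 1. Within that pair, a 1.4-fold higher number from compound 2 to compound 3 (0.15 log units; within the scatter), so exchanging heptyl for hydrogen on the saturated chain carbon bound to the carbonyl carbon leaves the two numbers within the scatter of each other.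

Compound 4 `O=C(Nc1cc(C(F)(F)F)cc(C(F)(F)F)c1)C1CCc2ccccc2N1` has not been measured. It differs from compound 1 in one place: hydrogen in place of (3-chlorophenyl)carbonyl on a nitrogen on an aromatic ring in a ring. Among the measured compounds shown here, no measured step removes the whole group from the nitrogen on the aromatic ring in a ring; the only step on that side of the molecule, a 1.4-fold higher number from compound 2 to compound 3 (0.15 log units; within the scatter), keeps a carbonyl there and merely varies the chain, and compounds 2 and 3 also carry a different amide partner than compound 1, so the large gap between compound 1 and the pair cannot be assigned to either part alone. The step from compound 1 to compound 4 is therefore expected to raise the number well beyond the scatter, a 9.6-fold higher number from compound 1 to compound 4 (0.98 log units; beyond the scatter). Compound 4 is estimated to give 6000 nM, with a range of 1500 nM to 40000 nM.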

Compound 4, concentration for 50% growth inhibition: 8700 nM
The estimate for compound 4 lay 1.5-fold (0.16 log units) below the measured number; the range from low to high includes it.
By their numbers in this assay, from the lowest: compound 1; then compound 4; then compounds 2 and 3 (each within the scatter of the next).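

In this assay, exchanging (3-chlorophenyl)carbonyl for hydrogen on the nitrogen on an aromatic ring in a ring gives a 14-fold higher number from compound 1 to compound 4 (1.14 log units; beyond the scatter) and is a large step, beyond the scatter. This is the series' only step that strips the whole group from that nitrogen, and it shows that this position can move the number, which the chain change alone did not show: a 1.4-fold higher number from compound 2 to compound 3 (0.15 log units; within the scatter) stays within the scatter while a carbonyl remains on the nitrogen. No measurement at hand accounts for the size of the step from compound 1 to compound 4.

From the compounds shown here alone, the step removes the chlorine, the aromatic ring and the carbonyl together, so the share of each remains open; a benzoyl group without chlorine or a benzyl group without the carbonyl on this nitrogen would separate them. Also open, going by these compounds, is how a chain carbonyl group such as those of compounds 2 and 3 would read on the nitrogen of compound 4, which keeps the amide partner of compound 1 rather than theirs.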